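A smaller amine on the amide side chain

The compounds below may be only part of what the source reports. "The series", "measured", "known", "first", "only" and "open" are said of these compounds alone.

Compound 1 `CC[C@@H](C)[C@H](NC(=O)c1ccc(C(CC)(CC)c2ccc(OCC(=O)C(C)(C)C)c(C)c2)n1CC)C(=O)OC` and compound 2 `CCN(CC)CCNC(=O)c1ccc(C(CC)(CC)c2ccc(OCC(=O)C(C)(C)C)c(C)c2)n1CC` share one core and differ only in the group carried by the amide-type nitrogen. In an assay on HL-60 cells for agonist activity at vitamin D3 receptor (Homo sapiens), read by microscopy, with a stated time of 96 h (on this read-out lower numbers stand for an effect already at smaller amounts and higher numbers for an effect only at larger amounts of compound), compound 1 gives 590 nM, and compound 2 gives 91 nM. Going by the values given here, that change, a 6.5-fold lower number from compound 1 to compound 2 (0.81 log units; beyond the scatter), is the only measured step so far, and it leaves compound 2 with the lowest number of the two.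

Compound 3 `CCn1c(C(=O)NCCN(C)C)ccc1C(CC)(CC)c1ccc(OCC(=O)C(C)(C)C)c(C)c1` keeps the chain of compound 2 and alters its end: dimethylamino in place of diethylamino on a saturated chain carbon, two bonds along the chain from an amide-type nitrogen. Among the compounds with values here, no measured step touches this part of the molecule. Within the data shown here, the one step in hand, a 6.5-fold lower number from compound 1 to compound 2 (0.81 log units; beyond the scatter), swapped the whole group on the amide-type nitrogen, so it says little about trimming the amine at the far end of an otherwise kept chain.

With nothing to point either way, the expectation is a step of no more than the usual scatter, which the estimated step of a 1.1-fold higher number from compound 2 to compound 3 (0.04 log units; within the scatter) reflects. Compound 3 is therefore estimated at about 100 nM, with a likely range from 40 nM to 250 nM.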

Compound 3, half-maximal effective concentration: 77 nM
Beside the measured number, compound 3's estimate is 1.3-fold (0.11 log units) above it; the range from low to high includes it.
By their numbers in this assay, from the lowest: compounds 3 and 2 (each within the scatter of the next); then compound 1.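

At this position, the two end groups cannot be told apart in this assay: dimethylamino in place of diethylamino on the same 2-aminoethyl-type chain gives a 1.2-fold lower number from compound 2 to compound 3 (0.07 log units; within the scatter). So the distance from the group in compound 1 does not depend on which of these two amines ends the chain, since the exchange of the whole group gives a 7.7-fold lower number from compound 1 to compound 3 (0.88 log units; beyond the scatter), much like the earlier 6.5-fold lower number from compound 1 to compound 2 (0.81 log units; beyond the scatter). Nothing measured here accounts for either the close match or the larger steps.

The compounds shown leave open how far the amine end can be varied before the number moves beyond the scatter, for example with a piperidine ring or a single methylamino at the end of the chain. They also leave open whether the nitrogen at the chain end is needed at all, which a chain ending in a hydroxyl or a carboxylic acid would address, and whether a longer chain carrying the same dimethylamino would give a similar number.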